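Replacing oxan-4-yl with 1-benzofuran-4-yl in compound 2

The compounds below may be only part of what the source reports. "The series", "measured", "known", "first", "only" and "open" are said of these compounds alone.

Measured in a physicochemical assay for solubility; on this read-out higher numbers stand for higher solubility and lower numbers for lower solubility:
Compound 1 `CNC(=O)c1cc(C(=O)NC2CC2)cn(Cc2cccc(C)c2)c1=O`: >= 205 ug/mL (a limit)
Compound 2 `CNC(=O)c1cc(C(=O)NC2CC2)cn(CC2CCOCC2)c1=O`: >= 165 ug/mL (a limit)

Compound 2 stands at a limit, >= 165 ug/mL, and not at a true number. Compound 3 `CNC(=O)c1cc(C(=O)NC2CC2)cn(Cc2cccc3occc23)c1=O` carries 1-benzofuran-4-yl in place of oxan-4-yl on a saturated chain carbon bound to an aromatic nitrogen. For the measured compounds named here, the only measured step bearing on this is a step that the two limits leave unreadable from compound 1 to compound 2, so no size can be taken from it. Compound 1, with its aromatic 3-methylphenyl, also stands at a limit, >= 205 ug/mL. A modest fall in this assay is therefore expected, possibly none beyond the scatter. The estimated change is an at least 1.2-fold lower number from compound 2 to compound 3 (0.10 log units; that floor lies within the scatter). Compound 3 is expected at 130 ug/mL, within an estimated range of 40 ug/mL to 300 ug/mL.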

Compound 3, solubility: >= 110 ug/mL
Compound 3 gave a limit, no number (the forecaster's own chance of this, stated with the estimate: 40%); the middle value does not contradict the limit.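

For the compounds shown here, compound 1, compound 2 and compound 3 each give only a limit in this assay, and no step among them can be read. From the compounds shown here alone, whether 3-methylphenyl, oxan-4-yl or 1-benzofuran-4-yl changes this read-out at all stays open.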